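A Hydroxy Group Added to Compound 1

A few compounds are considered here, and "the series" means these few. Any claim that something is new, unique, unknown or untested is made for them only; others in the source may bear on it.

Among the measured compounds shown here, compound 1 `O=c1c(Cc2coc3cccc(OCC4CCCCC4)c3c2=O)coc2ccccc12` carries the only numerical reading available so far. In a functional assay on NCI-H23 cells (Homo sapiens) for antiproliferative activity, read by XTT assay (on this read-out higher numbers stand for weaker inhibition and lower numbers for stronger inhibition), compound 1 gives 4130 nM. Compound 2 `O=c1c(/C=C/c2coc3ccccc3c2=O)coc2ccccc12` reads > 10000 nM in this assay, and this is a limit of the assay rather than a number. Its structure differs from that of compound 1 in more than one place, so the two values say nothing about a single change.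

Compound 3 `O=c1c(Cc2coc3cccc(OCC4CCCCC4)c3c2=O)coc2cc(O)ccc12` keeps the whole of compound 1 except at one point: hydroxy in place of hydrogen on an aromatic carbon. Hydroxy stands in place of hydrogen on an aromatic carbon of a six-membered aromatic ring of carbon only, part of a fused or bridged system of two rings. For the measured compounds named here, no measured pair shows what this change does, so the expectation starts from compound 1 at 4130 nM and no step beyond the scatter is expected in this assay, with neither direction favoured. The expected result is a 1.2-fold lower number from compound 1 to compound 3 (0.07 log units; within the scatter). Compound 3 is estimated at 3500 nM, with an expected range of 1000 nM to 10000 nM.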

Compound 3, half-maximal inhibitory concentration: 2150 nM
For compound 3 the middle estimate is 1.6-fold (0.21 log units) above the measured one; the range from low to high includes it.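

Among the compounds shown here, compound 3 gives the first comparison in which a single change can be read. In this assay, hydroxy in place of hydrogen on an aromatic carbon, meta to a fused ring and para to a fused ring, gives a 1.9-fold lower number from compound 1 to compound 3 (0.28 log units; within the scatter) with the rest of the structure unchanged. This position on the six-membered aromatic ring of carbon only therefore takes the added hydroxy without a step beyond the scatter, and nothing in the data shown bears on why the step has this size.

The compounds shown leave open whether another group at this same position, such as methoxy, an amine or a carboxylic acid, would stay within the scatter of compound 3 or move beyond it. They also leave open whether hydroxy on another aromatic carbon of the same ring would behave in the same way, since a single step at a single position supports no wider pattern.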